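Adding an isopropyl group to compound 2

The source may report more compounds than this note shows. Statements on the series, on what has been measured and on what is new or still open speak of the compounds shown alone.

compound 1 (`CSc1ccc(Nc2ncnc3occ(C)c23)cc1`): "not determined" (no result reported)
compound 2 (`COc1ccc(Nc2ncnc3occ(C)c23)cc1`): "not determined" (no result reported)
compound 3 (`CCc1ccc(N(C)c2ncnc3occ(C)c23)cc1`): 183 nM

These compounds share a core and differ in the groups attached to it. In a functional assay on MDA-MB-435 cells (Homo sapiens) for inhibition, read by sulforhodamine B assay, with a stated time of 48 h (a higher number here means that more compound is needed for the effect, a lower number that less compound is needed), compound 2 has no single number, and its entry reads "not determined" (no result reported). Going by the values given here, compound 1 is in the same position, so compound 3 provides the only measured value.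

The next compound is compound 4 (`COc1ccc(N(c2ncnc3occ(C)c23)C(C)C)cc1`). The change is isopropyl in place of hydrogen on a nitrogen on an aromatic ring. Among the compounds with values here, with no number for compound 2, the size of this step cannot be measured from its starting point, and no measured pair shows a comparable change.

The nearest guide is compound 3, at 183 nM, which also has a carbon group on that nitrogen but differs elsewhere too. A value near that of compound 3 is therefore expected, perhaps moderately higher, meaning that somewhat more compound would be needed. In this assay the estimated value for compound 4 is 300 nM, with an expected range of 50 nM to 2500 nM.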

Compound 4, half-maximal effective concentration: 504 nM
For compound 4 the middle estimate is 1.7-fold (0.23 log units) below the measured one; measured number inside the range.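

Going by these compounds alone, compound 2 has no single number, so in this assay no step to compound 4 can be read. What the isopropyl group on the nitrogen does by itself therefore stays open, and nothing shown accounts for the value of compound 4.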